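This account rests on a few compounds, and the source may have more. Where it says the series, first, only, none or still open, it means among the compounds named here.

Measured so far in a functional assay on cells (Cancer cell lines, Homo sapiens) for inhibition; a higher number here means a weaker inhibitor of growth, a lower number a stronger inhibitor of growth

compound 1 `N=C(N)N/N=C/c1c(-c2cc(Cl)sc2Cl)nc2n1CCS2` gives 22900 nM
compound 2 `N=C(N)N/N=C/c1c(-c2ccsc2)nc2sccn12` gives 31600 nM
compound 3 `Cc1cc(-c2nc3sccn3c2/C=N/NC(=N)N)c(C)s1` gives 33900 nM

These three values lie within the scatter of one another, so compound 1 stands level with compound 2 and compound 3 in this assay and no order can be read among them. Compound 4 `Cc1cc(-c2nc3n(c2/C=N/NC(=N)N)CCS3)c(C)s1` has not yet been measured. It keeps the core of compound 1 and carries 2,5-dimethylthiophen-3-yl in place of 2,5-dichlorothiophen-3-yl on an aromatic carbon. Among the measured compounds shown here, no measured pair makes this exchange directly. The nearest evidence is one step on the core of compound 2, with 2,5-dimethylthiophen-3-yl in place of thiophen-3-yl, and that step (a 1.1-fold higher number from compound 2 to compound 3 (0.03 log units; within the scatter)) lies within the scatter. Compound 3, which carries the same 2,5-dimethylthiophen-3-yl, gives 33900 nM and so stays within the scatter of compound 1 as well. No step beyond the scatter is therefore expected in this assay, and the estimated step (a 1.2-fold higher number from compound 1 to compound 4 (0.09 log units; within the scatter)) is a small one towards a higher number. The expected value for compound 4 is 28000 nM within an estimated range (15000 nM to 52000 nM).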

Compound 4, concentration for total growth inhibition: 47900 nM
Beside the measured number, compound 4's estimate is 1.7-fold (0.23 log units) below it, and the stated range covers the measured number.
By their numbers in this assay, from the lowest: compounds 1, 2, 3 and 4 (each within the scatter of the next, the first and the last beyond it).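

In this assay, 2,5-dimethylthiophen-3-yl in place of 2,5-dichlorothiophen-3-yl on an aromatic carbon gives a 2.1-fold higher number from compound 1 to compound 4 (0.32 log units; beyond the scatter), the only step shown that passes beyond the scatter, though it is a modest one. Among the compounds shown here, the position on the core of compound 1 therefore responds measurably to this exchange of groups, which the earlier compounds could not show: their one step, a different exchange on a different core, was a 1.1-fold higher number from compound 2 to compound 3 (0.03 log units; within the scatter), and it stayed within the scatter. Nothing available here accounts for the difference between the chlorine-bearing and the methyl-bearing group on this core.

The compounds shown leave open where plain thiophen-3-yl would stand on the core of compound 1, and so whether the step reflects the loss of the chlorine atoms, the arrival of the methyl groups, or both, and whether the same exchange would give a similar step on the core of compound 2. They also leave open how a phenyl ring, a methoxy group or an amine would read at this position.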